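Swapping carboxy for a dihydroxybenzyl group

A few compounds are considered here, and "the series" means these few. Any claim that something is new, unique, unknown or untested is made for them only; others in the source may bear on it.

Compound 1 `COc1cccc(Cc2cn(C3CC3)c3c(F)c(-c4cc(C)nc(C)c4)c(F)cc3c2=O)c1`: 20000 nM
Compound 2 `Cc1cc(-c2c(F)cc3c(=O)c(C(=O)O)cn(C4CC4)c3c2F)cc(C)n1`: 29000 nM

Among the measured compounds shown here, both compounds have been measured in a functional assay on P388 cells (Mus musculus) for cytotoxicity; on this read-out higher numbers stand for weaker inhibition and lower numbers for stronger inhibition. Compound 2, at 29000 nM, has only compound 1 to be compared with, and the two values cannot be told apart. The next compound, compound 3 `Cc1cc(-c2c(F)cc3c(=O)c(Cc4cc(O)ccc4O)cn(C4CC4)c3c2F)cc(C)n1`, keeps the core of compound 2 but carries 2,5-dihydroxybenzyl in place of carboxy on an aromatic carbon.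

For the measured compounds named here, one measured step bears on this change. It is a 1.5-fold higher number from compound 1 to compound 2 (0.16 log units; within the scatter), and it links carboxy with another substituted benzyl group, 3-methoxybenzyl. That step is small, so a benzyl group in this place need not give a number much different from carboxy. Going by the values given here, no measured compound carries the 2,5-dihydroxybenzyl group, however, so its own contribution is unknown and the range must stay wide. Overall, no shift beyond the scatter is expected in this assay.

The expected change is a 1.9-fold lower number from compound 2 to compound 3 (0.29 log units; within the scatter). For compound 3 the estimated value is 15000 nM, with an expected range of 4000 nM to 40000 nM.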

Compound 3, half-maximal inhibitory concentration: 360 nM
Beside the measured number, compound 3's estimate is 42-fold (1.62 log units) above it; the measured number lies below the stated range.
By their numbers in this assay, from the lowest: compound 3; then compounds 1 and 2 (each within the scatter of the next).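

In this assay, this position proves far from indifferent: 2,5-dihydroxybenzyl in place of carboxy gives an 81-fold lower number from compound 2 to compound 3 (1.91 log units; beyond the scatter) in this cell-based read-out, although carboxy and 3-methoxybenzyl could not be told apart. The benzyl link alone does not account for this large step: with the link kept, 2,5-dihydroxyphenyl in place of 3-methoxyphenyl gives a 56-fold lower number from compound 1 to compound 3 (1.74 log units; beyond the scatter) and so shows that the groups on the benzyl ring make a large difference here. No available measurement explains why this particular ring stands so far from the other two groups.

The two hydroxy groups arrive together, so the compounds shown cannot say whether one of them alone would be enough, or how an unsubstituted benzyl group or a benzyl group carrying two methoxy groups at those same ring places would compare. As far as these compounds go, it also remains open whether the saturated carbon link is needed, which a 2,5-dihydroxyphenyl ring attached directly to the core or a longer chain between ring and core would test.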